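The compounds below may be only part of what the source reports. "The series", "measured", "known", "first", "only" and "open" are said of these compounds alone.

Measured in an ADME assay on Vero cells (Chlorocebus sabaeus) for cytotoxicity, read by resazurin assay, with a stated time of 72 h; a lower number here means a stronger inhibitor, a higher number a weaker inhibitor:
compound 1 `O=C(CCN1CCN(c2ccc(F)cc2)CC1)c1ccccc1`: 13400 nM
compound 2 `O=C(CCN1CCN(c2ccc(F)cc2)CC1)c1ccc(Br)cc1`: 99500 nM

Compound 2 holds the higher of the two numbers in this assay. Compound 3 `O=C(CCN1CCN(c2ccc(F)cc2)CC1)c1ccc(C(F)(F)F)cc1` carries trifluoromethyl in place of bromo on an aromatic carbon, para to a large group: trifluoromethyl in place of bromo on an aromatic carbon. Within the data shown here, the one measured step that bears on this change is a 7.4-fold higher number from compound 1 to compound 2 (0.87 log units; beyond the scatter), a modest step for bromo in place of hydrogen. Among the measured compounds shown here, no measured pair compares bromo with trifluoromethyl directly, so no change beyond the scatter is expected. The expected step is a 1.4-fold lower number from compound 2 to compound 3 (0.15 log units; within the scatter). The estimate for compound 3 is 70000 nM, with an expected range of 25000 nM to 160000 nM.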

Compound 3, half-maximal inhibitory concentration: 28500 nM
Compound 3: middle estimate off by 2.5-fold (0.39 log units), on the high side; the measured number falls inside the stated range.
By their numbers in this assay, from the lowest: compound 1; then compound 3; then compound 2.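

On the aromatic carbon para to a large group, bromo and trifluoromethyl are not interchangeable: the number falls with a 3.5-fold lower number from compound 2 to compound 3 (0.54 log units; beyond the scatter). Trifluoromethyl still stands above hydrogen, with a 2.1-fold higher number from compound 1 to compound 3 (0.33 log units; beyond the scatter), so both substituents shown raise the number over the unsubstituted compound 1, bromo the further of the two. Nothing measured here accounts for the difference between the two groups.

Going by these compounds, whether the same rise holds for an amine, a methoxy group or a carboxylic acid on this carbon remains open. So does the effect of bromo or trifluoromethyl on the other carbons of this ring.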